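The source may report more compounds than this note shows. Statements on the series, on what has been measured and on what is new or still open speak of the compounds shown alone.

Compound 3 `O=C(O)c1ccccc1-c1ccc(CCc2ncc(Cc3cccc(F)c3)[nH]2)cc1` gives 159 nM in an in vitro functional assay on cells for agonist activity at Bombesin receptor subtype-3 (Homo sapiens), read by luminescence and calcium flux; a lower number here means that less compound is needed, a higher number that more compound is needed for the effect. Among the three compounds measured so far it stands second highest: compound 2 `O=C(O)c1ccccc1-c1ccc(CCc2ncc(Cc3ccccc3Cl)[nH]2)cc1` gives 292 nM, and the step of a 1.8-fold lower number from compound 2 to compound 3 (0.26 log units; within the scatter) lies within the scatter, while compound 1 `O=C(O)c1ccccc1-c1ccc(CCc2ncc(CC3CCCCC3)[nH]2)cc1` gives 41 nM, the lowest number of the set, with a 3.9-fold higher number from compound 1 to compound 3 (0.59 log units; beyond the scatter).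

Compound 4 `CC(C)(C)c1cnc(CCc2ccc(-c3ccccc3C(=O)O)cc2)[nH]1` differs from compound 3 by tert-butyl in place of 3-fluorobenzyl on an aromatic carbon. Among the compounds with values here, the steps that bear on this change are a 3.9-fold higher number from compound 1 to compound 3 (0.59 log units; beyond the scatter) and a 7.1-fold higher number from compound 1 to compound 2 (0.85 log units; beyond the scatter), both showing that the saturated cyclohexyl on the saturated chain carbon gave a lower number than either substituted phenyl. Within the data shown here, the tert-butyl entering compound 4 is likewise saturated and carries no ring, but it has only 4 heavy atoms and sits directly on the aromatic carbon of the five-membered ring rather than on a chain carbon; no measured step covers such a shortening. Compound 4 is therefore expected to move modestly downward, a 1.6-fold lower number from compound 3 to compound 4 (0.20 log units; within the scatter), towards compound 1 but not matching it, with an estimate of 100 nM and a range from 30 nM to 350 nM.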

Compound 4, half-maximal effective concentration: 4330 nM
Compound 4: the middle estimate sits 43-fold (1.64 log units) below what was measured; the measured number lies above the stated range.
By their numbers in this assay, from the lowest: compound 1; then compounds 3 and 2 (each within the scatter of the next); then compound 4.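

At this aromatic carbon of the five-membered ring, tert-butyl gives a far higher number in this assay than each of the three groups that carry a ring on a saturated chain carbon (a 27-fold higher number from compound 3 to compound 4 (1.44 log units; beyond the scatter); a 15-fold higher number from compound 2 to compound 4 (1.17 log units; beyond the scatter); a 110-fold higher number from compound 1 to compound 4 (2.02 log units; beyond the scatter)). All three steps are large, and each exceeds every step among compound 1, compound 2 and compound 3, so a saturated group at this position does not by itself give a low number. Nothing measured here accounts for the size of these steps.

The compounds shown do not separate the loss of the ring from the loss of the chain carbon, since tert-butyl differs in both. A neopentyl group or a phenyl ring set directly on this carbon would pull these two changes apart, and a cyclohexylethyl group would show whether a longer chain is tolerated.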